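Removing a methyl from a phenol oxygen in growth inhibitors

The compounds below may be only part of what the source reports. "The series", "measured", "known", "first", "only" and "open" are said of these compounds alone.

Four compounds share a common core and were compared in a functional assay on A549 cells (Homo sapiens) for inhibition, read by sulforhodamine B assay, with a stated time of 48 h; a higher number here means a weaker inhibitor of growth, a lower number a stronger inhibitor of growth. Compound 1 `COc1cc(-c2nn(-c3cccc(NC(=O)Nc4cc(C(F)(F)F)cc(C(F)(F)F)c4)c3)cc2-c2ccncc2)ccc1Cl` gives 527 nM in this assay. Compound 2 `O=C(Nc1cccc(-n2cc(-c3ccncc3)c(-c3ccc(Cl)c(O)c3)n2)c1)Nc1cc(C(F)(F)F)cc(C(F)(F)F)c1` carries one change, (hydrogen in place of methyl on an oxygen on an aromatic ring), and in this assay compound 2 gives 298 nM; the measured step is a 1.8-fold lower number from compound 1 to compound 2 (0.25 log units; within the scatter). Compound 3 `COc1cc(-c2nn(-c3cccc(NC(=O)Nc4ccc(Cl)c(C(F)(F)F)c4)c3)cc2-c2ccncc2)ccc1Cl` gives 1020 nM in this assay, the highest of the three numbers. The difference between the core of compound 3 and the core of compound 1 is not broken down here.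

Compound 4 `O=C(Nc1cccc(-n2cc(-c3ccncc3)c(-c3ccc(Cl)c(O)c3)n2)c1)Nc1ccc(Cl)c(C(F)(F)F)c1` has not been measured. It differs from compound 3 by hydrogen in place of methyl on an oxygen on an aromatic ring, the same change that separates compound 1 and compound 2 at the same place. The expectation for compound 4 rests on that earlier step: because the change produced a 1.8-fold lower number from compound 1 to compound 2 (0.25 log units; within the scatter), a step of about the same size, a 1.7-fold lower number from compound 3 to compound 4 (0.23 log units; within the scatter), is expected here, which remains within the scatter. In this assay compound 4 is therefore estimated to give 600 nM, with a likely span from 300 nM to 1200 nM.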

Compound 4, concentration for 50% growth inhibition: 927 nM
Beside the measured number, compound 4's estimate is 1.5-fold (0.19 log units) below it; measured number inside the range.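

In this assay the change from methoxy to hydroxy gives a 1.1-fold lower number from compound 3 to compound 4 (0.04 log units; within the scatter) and so leaves compound 3 and compound 4 indistinguishable within the normal variation of the measurement. The step on this core agrees with the step seen earlier on the core of compound 1, so the change behaves alike on both cores as far as this assay can tell: the same change on two cores in this assay, a 1.8-fold lower number (0.25 log units; within the scatter) from compound 1 to compound 2 and a 1.1-fold lower number (0.04 log units; within the scatter) from compound 3 to compound 4, 1.6-fold (0.21 log units) apart, within the scatter of two such steps. This agreement is a weak kind of transfer, since neither step stands clear of the scatter; the two pairs show that swapping methoxy for hydroxy made no measurable difference on either core, but they do not show that the hydroxy group truly improves growth inhibition, or that the same would hold on any other core.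

Still open, from the compounds shown here alone, is how an amine, an ethoxy group or a fluorine atom in that same place would compare with the methoxy and hydroxy groups. Also open, going by these compounds, is whether a larger step would appear on a core with different groups on the far side of the urea.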